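The source may hold more compounds than are shown below. What is called first, only, known or untested is meant among the compounds shown, and "the series" means these compounds.

Measured compounds:
Compound 1, `Clc1cccc2c1CC2CCCN1CCN(c2cccc3c2OCCO3)CC1`: 1.25 mg/kg
Compound 2, `Fc1cccc2c1CC2CN1CCN(c2cccc3c2OCCO3)CC1`: > 1.25 mg/kg

In an assay for activation of Adrenergic receptor alpha-1 (Rattus norvegicus) (on this read-out lower numbers stand for an effect already at smaller amounts and higher numbers for an effect only at larger amounts of compound), compound 1 gives 1.25 mg/kg, the only plain number shown for this assay. For compound 2 the assay reports a limit rather than a number: > 1.25 mg/kg marks the edge of what was tested, namely (the limit of > 1.25 mg/kg in this assay, at which 1 of the 2 values shown sits). Going by the values given here, no step between two measured compounds exists here, so the size of any change in this assay cannot be read from the data. Compound 3, `c1ccc2c(c1)CCC2CCCN1CCN(c2cccc3c2OCCO3)CC1`, differs from compound 1 in one place: a group of 9 heavy atoms (9 carbon; one five-membered non-aromatic ring of carbon only, one six-membered aromatic ring of carbon only) in place of a group of 9 heavy atoms (8 carbon, 1 chlorine; one four-membered non-aromatic ring of carbon only, one six-membered aromatic ring of carbon only), on a saturated chain carbon, three bonds along the chain from an amine nitrogen in a ring. Among the compounds with values here, with no measured step to lean on, the change is expected to make no difference beyond the usual scatter in this assay. Compound 3 is expected to give about 1.5 mg/kg, within a range from 0.5 mg/kg to 4.5 mg/kg. This estimate corresponds to an expected step of a 1.2-fold higher number from compound 1 to compound 3 (0.08 log units; within the scatter) in this assay.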

Compound 3, dose for half-maximal effect: 0.23 mg/kg
For compound 3 the middle estimate is 6.5-fold (0.81 log units) above the measured one; measured number below the stated range.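

In this assay, 2,3-dihydro-1H-inden-1-yl in place of the chlorine-bearing group gives a 5.4-fold lower number from compound 1 to compound 3 (0.74 log units; beyond the scatter) on the saturated chain carbon, three bonds along the chain from an amine nitrogen in a ring. Going by these compounds alone, this is the first readable step, and it shows that the read-out responds to a change at this position even though both groups have the same count of heavy atoms, no hydrogen-bond donors or acceptors and no net charge. The data give no cause for this step, and with the chlorine and the four-membered ring leaving together, they do not divide it between those two features.

From the compounds shown here alone, what a 2,3-dihydro-1H-inden-1-yl group carrying a chlorine would give remains open. So does whether an amine or carboxylic acid on this group, or a longer chain, would move the number in this assay at all.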